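The source may hold more compounds than are shown below. What is called first, only, known or untested is meant among the compounds shown, and "the series" means these compounds.

Compounds measured in an in vitro ADME assay on microsomes from liver (Rattus norvegicus) for metabolic stability, tested at 1 uM; a higher number here means that the compound lasts longer, a lower number that the compound disappears faster:
compound 1 `O=C(c1ccc(Cl)nc1)N1CCC(NS(=O)(=O)c2cc(S(=O)(=O)c3ccccc3)ccc2C(F)(F)F)CC1`: 0.15 h
compound 2 `CN(C)c1ccc(C(=O)N2CCC(NS(=O)(=O)c3cc(S(=O)(=O)c4ccccc4)ccc3C(F)(F)F)CC2)cn1`: 0.0333 h

Compound 2 stands lowest of the two numbers; the nearest is compound 1, reached by a 4.5-fold lower number from compound 1 to compound 2 (0.65 log units; beyond the scatter) in the other direction. Compound 3 `CC(C)(O)CCN1CCC(NS(=O)(=O)c2cc(S(=O)(=O)c3ccccc3)ccc2C(F)(F)F)CC1` carries the change (3-hydroxy-3-methylbutyl in place of (6-(dimethylamino)pyridin-3-yl)carbonyl on an amine nitrogen in a ring). No measured step bears on this change: the only step shown concerns a chloro-to-dimethylamino exchange at a different place, and it was modest. A modest rise is expected for compound 3, as a 3.0-fold higher number from compound 2 to compound 3 (0.48 log units; beyond the scatter). Compound 3 is estimated at 0.1 h, with a range of 0.03 h to 0.4 h.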

Compound 3, half-life: 0.05 h
Beside the measured number, compound 3's estimate is 2.0-fold (0.30 log units) above it; the measured number falls inside the stated range.
By their numbers in this assay, from the lowest: compounds 2 and 3 (each within the scatter of the next); then compound 1.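

In this assay, 3-hydroxy-3-methylbutyl in place of (6-(dimethylamino)pyridin-3-yl)carbonyl on the amine nitrogen in a ring gives a 1.5-fold higher number from compound 2 to compound 3 (0.18 log units; within the scatter), so this open chain and that acyl group cannot be told apart here. Against the (6-chloropyridin-3-yl)carbonyl group, the same chain gives a 3.0-fold lower number from compound 1 to compound 3 (0.48 log units; beyond the scatter), so the outcome at this nitrogen depends on which group leaves. No measurement at hand accounts for these steps. Open, from the compounds shown here alone, is how a simple alkyl chain without the hydroxyl, or a carboxylic acid on the chain, would compare on this nitrogen.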